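A few compounds are considered here, and "the series" means these few. Any claim that something is new, unique, unknown or untested is made for them only; others in the source may bear on it.

Compound 2 `CCCCCC#Cc1cc2cn(COCCO)c(=O)nc2o1` is the starting point. In a functional assay on HEL cells (Homo sapiens), read by microscopy (a lower number here means that less compound is tolerated, a higher number that more compound is tolerated), compound 2 gives >= 100000 nM, which is a limit of the assay rather than a number. Compound 1 `CCCCCCCCC#Cc1cc2cn(COCCO)c(=O)nc2o1` gives >= 20000 nM in this assay, also a limit. Compound 3 `CCCCCCCCCC#Cc1cc2cn(COCCO)c(=O)nc2o1` gives >= 20000 nM, again a limit. The steps between these three, a step that the two limits leave unreadable from compound 1 to compound 2, a step that the two limits leave unreadable from compound 2 to compound 3 and a step that the two limits leave unreadable from compound 1 to compound 3, cannot be sized, as the limit of >= 100000 nM in this assay, at which 1 of the 3 values shown sits, and the limit of >= 20000 nM in this assay, at which 2 of the 3 values shown sit, show. Compound 4 `CCCCc1cc2cn(COCCO)c(=O)nc2o1` is not yet measured; it differs from compound 2 by butyl in place of hept-1-yn-1-yl on an aromatic carbon. Going by the values given here, no measured step gives a readable size for such a change, so no step beyond the scatter can be expected in either direction. Compound 4 is therefore estimated at 40000 nM, within 15000 nM to 120000 nM. That estimate means an expected step of an at least 2.5-fold lower number from compound 2 to compound 4 (0.39 log units; beyond the scatter).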

Compound 4, minimum cytotoxic concentration: > 400000 nM
Compound 4: only a limit was reported (the forecaster's own chance of this, stated with the estimate: 80%); middle value at least 10-fold (1.00 log units) from the limit.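

The step from compound 2 to compound 4 cannot be read: both values are limits, not numbers. The compounds shown leave open the actual concentration at which any of them becomes toxic, and whether changing the chain alters it.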